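Aryloxy swap on a benzimidazole acid: expected solubility

The compounds below may be only part of what the source reports. "The series", "measured", "known", "first", "only" and "open" are said of these compounds alone.

Compound 1, `Cc1ccc(Oc2ccc3nc(COc4cccc(C(=O)O)c4)n(C)c3n2)c(C)c1`: 0.9 ug/mL
Compound 2, `Cc1ccc(Oc2cc3c(cn2)nc(COc2cccc(C(=O)O)c2)n3C)cc1`: 360 ug/mL
Compound 3, `Cn1c(COc2cccc(C(=O)O)c2)nc2ccc(Oc3cc(Cl)ccn3)cc21`: 11 ug/mL

In a physicochemical assay for solubility, read by HPLC, measured as thermodynamic solubility, with a stated time of 4 h, at pH 6.8 (a lower number here means a less soluble compound, a higher number a more soluble compound), compound 3 sits second highest of the three numbers. Its nearest neighbour is compound 1, which gives 0.9 ug/mL, a gap beyond the scatter. Furthest from it is compound 2, which gives 360 ug/mL, again well beyond the scatter. Compound 3 itself gives 11 ug/mL in this assay.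

Compound 4, `Cc1cnc(Oc2ccc3nc(COc4cccc(C(=O)O)c4)n(C)c3c2)c(F)c1`, differs from compound 3 in a single place: 3-fluoro-5-methylpyridin-2-yl in place of 4-chloropyridin-2-yl on an oxygen on an aromatic ring. The rest of the molecule, including the acid and the core shared with compound 3, is unchanged. No pair of measured compounds here differs by only such a swap, so the size of this step is not yet known from the numbers shown. A halogen is exchanged for another halogen and a methyl is added on the same pyridine ring, and the hydrogen-bond donor and acceptor counts stay the same, so the account expects compound 4 to move from compound 3 by a 1.4-fold lower number from compound 3 to compound 4 (0.14 log units; within the scatter), a step estimated to stay within the scatter or tend slightly lower. Compound 4 is therefore expected to give about 8 ug/mL in this assay, within a range from 2 ug/mL to 30 ug/mL.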

Compound 4, solubility: 9.2 ug/mL
Compound 4: middle estimate off by 1.2-fold (0.06 log units), on the low side; measured number inside the range.
By their numbers in this assay, from the lowest: compound 1; then compounds 4 and 3 (each within the scatter of the next); then compound 2.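

Set on an oxygen on an aromatic ring, 3-fluoro-5-methylpyridin-2-yl in place of 4-chloropyridin-2-yl gives a 1.2-fold lower number from compound 3 to compound 4 (0.08 log units; within the scatter) in this assay, the first single-place step in this small set, and it shows that these two pyridine groups cannot be told apart in this read-out. Among these compounds, compound 1 and compound 2 could not show this, as each differs from compound 3 in more than one place, so no step to either can be read and their values say nothing about this swap. Nothing measured here offers an explanation for how close compound 3 and compound 4 stand.

As far as these compounds go, the swap changes the halogen and adds a methyl in one step, so what each change would do alone remains open, and a single pair cannot say whether the same swap would give a similar step on the core of compound 1 or of compound 2. Also open, from the compounds shown here alone, is whether a pyridine ring carrying an amine or a longer chain, in place of these groups on the same oxygen, would stay within the scatter of compound 3.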